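A few compounds are considered here, and "the series" means these few. Any claim that something is new, unique, unknown or untested is made for them only; others in the source may bear on it.

Compound 1 `COc1ccc(C(=O)Nc2ccccc2F)cc1OC1CCCC1` is an amide built on the shared core. For the measured compounds named here, in an assay on isolated protein for inhibition of phosphodiesterase 4A (Sus scrofa) (a lower number here means a stronger inhibitor, a higher number a weaker inhibitor), compound 1 gives 10700 nM, the only numerical value among the two measured compounds. Compound 2 `COc1ccc(C(=O)Oc2c(Cl)cccc2Cl)cc1OC1CCCC1`, an ester on the same core, shows in this assay only a limit, > 1000000 nM, which is not a number (the limit of > 1000000 nM in this assay, at which 1 of the 2 values shown sits). Compound 3 `COc1ccc(C(=O)Nc2ccccn2)cc1OC1CCCC1` has not yet been measured; it differs from compound 1 in one place (pyridin-2-yl in place of 2-fluorophenyl on an amide-type nitrogen), carrying pyridin-2-yl in place of 2-fluorophenyl on an amide-type nitrogen. Going by the values given here, no step between two measured compounds is available to guide the expectation, so the change from compound 1 to compound 3 in this assay is expected to be small, at most a modest gain in potency and possibly nothing beyond the usual scatter. The step of a 2.1-fold lower number from compound 1 to compound 3 (0.33 log units; beyond the scatter) is the size expected. Compound 3 is estimated at 5000 nM, within a range of 1500 nM to 20000 nM.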

Compound 3, half-maximal inhibitory concentration: 1000 nM
Estimate against measurement, compound 3: 5.0-fold (0.70 log units) above; measured number outside the range, below it.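

Replacing 2-fluorophenyl with pyridin-2-yl on the amide-type nitrogen gives an 11-fold lower number from compound 1 to compound 3 (1.03 log units; beyond the scatter) in this assay, so this position responds strongly to the group it carries, something compound 1 alone could not show. The swap makes two changes at once: the fluorine leaves, and a carbon-only aromatic ring gives way to one with a ring nitrogen, counted as a hydrogen-bond acceptor. Nothing measured here explains why the number falls.

From the compounds shown here alone, whether the ring nitrogen or the loss of fluorine accounts for the step stays open; plain phenyl, which has neither, would help separate the two, and pyridin-3-yl would show whether the place of the ring nitrogen matters. Compound 2 gives only a limit, > 1000000 nM, and differs from compound 1 in more than one place, so it cannot settle either question.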